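Fluoro for methyl on the aryl of compound 2

The compounds below may be only part of what the source reports. "The series", "measured", "known", "first", "only" and "open" are said of these compounds alone.

Measured compounds:
compound 1 `C#CCO/N=C/c1c(-c2ccc(C)cc2)nc2c(C)cccn12` — 40 mg/kg
compound 2 `Cc1ccc(-c2nc3ccc(Br)cn3c2/C=N/OCc2cn(Cc3ccc([N+](=O)[O-])cc3)nn2)cc1` — 100 mg/kg
compound 3 `COc1ccc(Cn2cc(CO/N=C/c3c(-c4ccc(C)cc4)nc4c(C)cccn34)nn2)cc1` — 100 mg/kg

In a functional assay on the whole organism (strain NMRI) with Mus musculus as the target, in the maximal electroshock model, with a stated time of 4 h (on this read-out higher numbers stand for an effect only at larger amounts of compound and lower numbers for an effect already at smaller amounts), compound 2 gives 100 mg/kg. Compound 3 gives 100 mg/kg, a number level with that of compound 2 within the usual scatter, and the two share the highest number of the three. Compound 1 gives 40 mg/kg, a lower number, and that difference lies beyond the scatter.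

Compound 4 `O=[N+]([O-])c1ccc(Cn2cc(CO/N=C/c3c(-c4ccc(F)cc4)nc4ccc(Br)cn34)nn2)cc1` has not been measured. It differs from compound 2 by fluoro in place of methyl on an aromatic carbon. Among the measured compounds shown here, no measured pair shows this change, so no step can be read from the data, and on this assay the expectation is a step of no more than the scatter, in no particular direction. The estimate for compound 4 is therefore 100 mg/kg (range 40 mg/kg to 250 mg/kg), which as a step means no change at the digits printed from compound 2 to compound 4 (within the scatter).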

Compound 4, minimum effective dose: 100 mg/kg
For compound 4 middle estimate and measured number coincide at the digits printed; measured number inside the range.
By their numbers in this assay, from the lowest: compound 1; then compounds 2, 3 and 4 (each within the scatter of the next).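

In this assay, among the compounds shown here, exchanging 4-methylphenyl for 4-fluorophenyl gives no change at the digits printed from compound 2 to compound 4 (within the scatter), the only step here that can be read at a single place. The earlier compounds shown here differed in several places and said nothing about this position on its own, whereas this pair shows that fluoro can stand in place of methyl on this aromatic carbon, para to a large group, without a change beyond the scatter. Nothing shown explains this result. The compounds shown leave open whether an amine or a carboxylic acid at this position would shift the number, and whether the same exchange would hold on the core of compound 3.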